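This account rests on a few compounds, and the source may have more. Where it says the series, first, only, none or still open, it means among the compounds named here.

Compound 3 `CC1CCN(C(=O)c2cccc(N/C(=N/O)c3ccc4occc4c3)c2)CC1` stands at the edge of what an assay on isolated protein for inhibition of Indoleamine 2,3-dioxygenase 1 (Homo sapiens), read by spectrophotometry (on this read-out higher numbers stand for weaker inhibition and lower numbers for stronger inhibition), can report: in this assay compound 3 gives > 30000 nM, a limit rather than a number. Compound 1 `O/N=C(/Nc1ccccc1)c1ccc2occc2c1` likewise gives only a limit in this assay, > 30000 nM. Compound 2 `O/N=C(/Nc1cccc(C(F)(F)F)c1)c1ccc2occc2c1`, bearing a trifluoromethyl group, gives 1200 nM in this assay. The change to compound 4 `CCCCOc1cccc(N/C(=N/O)c2ccc3occc3c2)c1` is butoxy in place of (4-methylpiperidin-1-yl)carbonyl on an aromatic carbon. Among the measured compounds shown here, two measured steps bear on it: an at least 25-fold lower number from compound 1 to compound 2 (1.39 log units; beyond the scatter) and an at least 25-fold higher number from compound 2 to compound 3 (1.39 log units; beyond the scatter), the latter ending at the limit of > 30000 nM in this assay, at which 2 of the 3 values shown sit. Butoxy, like trifluoromethyl, brings no ring and no carbonyl, so a return toward the number of compound 2 is plausible. For compound 4 the expected step is an at least 5.0-fold lower number from compound 3 to compound 4 (0.69 log units; beyond the scatter). The estimate for compound 4 is 6000 nM, within 1500 nM to 30000 nM.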

Compound 4, half-maximal inhibitory concentration: > 30000 nM
Compound 4 ended at the assay's limit; the forecaster's own chance of this, stated with the estimate: 35%; middle value at least 5.0-fold (0.69 log units) away from the limit.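

Removing the ring and the carbonyl of compound 3 is not enough at this position: with butoxy there, the result is an at least 25-fold higher number from compound 2 to compound 4 (1.39 log units; beyond the scatter) and trifluoromethyl remains the only group shown here with a readable value. The steps linking compound 4 to compound 1 and to compound 3 cannot be read; each has a limit at both ends. Compound 4 adds to the cluster at the top of the scale: the limit of > 30000 nM in this assay, at which 3 of the 4 values shown sit.

From the compounds shown here alone, whether a short chain such as methoxy, or a single chlorine atom, would come close to compound 2 at 1200 nM remains open. So does any ranking among compound 1, compound 3 and compound 4.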